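The source may report more compounds than this note shows. Statements on the series, on what has been measured and on what is new or still open speak of the compounds shown alone.

Measured compounds in the series:

- compound 1 `CC(C)COC(=O)Nc1ccc([Se][Se]c2ccc(NC(=O)OCC(C)C)cc2)cc1`: 80500 nM
- compound 2 `CCCOC(=O)Nc1ccc([Se]C#N)cc1`: 67500 nM
- compound 3 `CCOC(=O)Nc1ccc([Se][Se]c2ccc(NC(=O)OCC)cc2)cc1`: 68300 nM

In a functional assay on MCF7 cells (Homo sapiens) for cytotoxicity, read by MTT assay, with a stated time of 72 h (on this read-out lower numbers stand for higher toxicity in this test and higher numbers for lower toxicity in this test), compound 2 carries the lowest of the three numbers, yet compound 3 and compound 1 both sit within the scatter of it, so the three numbers are not separated by this test. Compound 4 `CC(C)COC(=O)Nc1ccc([Se]C#N)cc1` is the next member: it differs from compound 2 by methyl in place of hydrogen on a saturated chain carbon bound to two saturated chain carbons. Among the measured compounds shown here, no measured pair isolates this change, and the values of compound 1 and compound 3 show only that the two chain lengths on the other scaffold fall within the scatter of each other. Expectation for the step from compound 2 to compound 4 in this assay: none beyond the scatter, a 1.0-fold higher number from compound 2 to compound 4 (0.02 log units; within the scatter). Compound 4 is thus estimated at 70000 nM, with a range from 35000 nM to 140000 nM.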

Compound 4, concentration lethal to 50% of the cells: 73000 nM
Beside the measured number, compound 4's estimate is 1.0-fold (0.02 log units) below it, within the range that was stated.
By their numbers in this assay, from the lowest: compounds 2, 3, 4 and 1 (each within the scatter of the next).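

In this assay, methyl in place of hydrogen on a saturated chain carbon bound to two saturated chain carbons gives a 1.1-fold higher number from compound 2 to compound 4 (0.03 log units; within the scatter). Among the compounds shown here, this is the first measured pair to isolate the change, and it shows that propyl to isobutyl does not separate the two compounds in this test. No supporting measurement bears on this result.

Open, on these data alone, is whether a longer chain, a benzyl group or an amine on the chain would separate from compound 2 in this assay.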